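The source may report more compounds than this note shows. Statements on the series, on what has been measured and on what is new or still open speak of the compounds shown alone.

Measured compounds:
Compound 1 `CC[C@H]1OC(=O)[C@H](C)[C@@H](O[C@H]2C[C@@](C)(OC)[C@@H](OCCCNC(=O)COC)[C@H](C)O2)[C@H](C)[C@@H](O[C@@H]2O[C@H](C)C[C@H](N(C)C)[C@H]2O)[C@](C)(O)C[C@@H](C)CN(C)[C@H](C)[C@@H](O)[C@]1(C)O` gives 2.16 in a physicochemical assay for lipophilicity, read by HPLC, measured as chromatographic lipophilicity, at pH 7.4; on this read-out higher numbers stand for higher lipophilicity and lower numbers for lower lipophilicity.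
Compound 2 `CCCCCCCC(=O)NCCCO[C@H]1[C@H](C)O[C@@H](O[C@H]2[C@H](C)[C@@H](O[C@@H]3O[C@H](C)C[C@H](N(C)C)[C@H]3O)[C@](C)(O)C[C@@H](C)CN(C)[C@H](C)[C@@H](O)[C@](C)(O)[C@@H](CC)OC(=O)[C@@H]2C)C[C@@]1(C)OC` gives 4.1 in this assay.
Compound 3 `CCC(=O)NCCCO[C@H]1[C@H](C)O[C@@H](O[C@H]2[C@H](C)[C@@H](O[C@@H]3O[C@H](C)C[C@H](N(C)C)[C@H]3O)[C@](C)(O)C[C@@H](C)CN(C)[C@H](C)[C@@H](O)[C@](C)(O)[C@@H](CC)OC(=O)[C@@H]2C)C[C@@]1(C)OC` gives 2.54 in this assay.

Compound 3 therefore stands second highest of the three: the step of a number 0.38 log units higher from compound 1 to compound 3 (beyond the scatter) is modest, while the step of a number 1.56 log units lower from compound 2 to compound 3 (beyond the scatter) is large. Compound 4 `CC[C@H]1OC(=O)[C@H](C)[C@@H](O[C@H]2C[C@@](C)(OC)[C@@H](OCCCNC(=O)c3c(C)nn(C)c3Cl)[C@H](C)O2)[C@H](C)[C@@H](O[C@@H]2O[C@H](C)C[C@H](N(C)C)[C@H]2O)[C@](C)(O)C[C@@H](C)CN(C)[C@H](C)[C@@H](O)[C@]1(C)O` differs from compound 3 in one place: 5-chloro-1,3-dimethyl-1H-pyrazol-4-yl in place of ethyl on a carbonyl carbon. Both measured steps change the same amide tail, so both bear on this change. The entering group is larger than the ethyl it replaces but carries two hydrogen-bond acceptors, so a moderate rise in this assay is expected, a number 0.66 log units higher from compound 3 to compound 4 (beyond the scatter). Compound 4 is estimated at 3.2, with a likely range from 2.6 to 3.8.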

Compound 4, distribution coefficient: 2.52
Estimate against measurement, compound 4: 0.68 log units above; measured number outside the range, below it.
By their numbers in this assay, from the lowest: compound 1; then compounds 4 and 3 (each within the scatter of the next); then compound 2.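

In this assay, the first ring shown on this carbonyl carbon gives a number 0.02 log units lower from compound 3 to compound 4 (within the scatter) and so reads level with ethyl: 8 heavy atoms in place of 2 need not move the number, as the chain steps might have suggested. The same ring, set against other tails, gives a number 1.58 log units lower from compound 2 to compound 4 (beyond the scatter) for heptyl and a number 0.36 log units higher from compound 1 to compound 4 (beyond the scatter) for methoxymethyl. No measurement shown explains this result. A single ring cannot show whether phenyl, or the pyrazole without its chlorine, would read the same at this position.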